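Taking the chloro off compound 2

The compounds below may be only part of what the source reports. "The series", "measured", "known", "first", "only" and "open" are said of these compounds alone.

In an ADME assay on THP-1 cells (Homo sapiens) for cytotoxicity, read by trypan blue exclusion, with a stated time of 48 h (a higher number here means a weaker inhibitor of growth, a lower number a stronger inhibitor of growth), compound 1 `Cc1ccc(CNCc2cc(C)n(-c3ccc(Cl)cc3)c2C)cc1` gives 6.1 ug/mL while compound 2 `Cc1cc(CNCc2ccc(Cl)cc2)c(C)n1-c1ccc(Cl)cc1` gives 18 ug/mL and so holds the higher of the two numbers. Among the compounds with values here, these two differ by chloro in place of methyl on an aromatic carbon, which makes up the single measured step: a 3.0-fold higher number from compound 1 to compound 2 (0.47 log units; beyond the scatter) (modest, and beyond the scatter).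

Compound 3 `Cc1cc(CNCc2ccccc2)c(C)n1-c1ccc(Cl)cc1` is not yet measured. It departs from compound 2 by hydrogen in place of chloro on an aromatic carbon. Within the data shown here, no measured compound carries hydrogen at that carbon, so the only guide is the step at the same place, where the chloro of compound 2 came with the higher number in a 3.0-fold higher number from compound 1 to compound 2 (0.47 log units; beyond the scatter) (a step from methyl, not from hydrogen). Losing the chloro is therefore expected to lower the number somewhat, by no more than a step of similar size. The expected change is a 1.6-fold lower number from compound 2 to compound 3 (0.21 log units; within the scatter) (an estimate that may well not clear the scatter). The estimate for compound 3 is 11 ug/mL with an expected range from 5 ug/mL to 26 ug/mL (both ends estimated).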

Compound 3, concentration for 50% growth inhibition: 7.2 ug/mL
Compound 3: the middle estimate sits 1.5-fold (0.18 log units) above what was measured; the measured number falls inside the stated range.
By their numbers in this assay, from the lowest: compounds 1 and 3 (each within the scatter of the next); then compound 2.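

In this assay, removing the chloro gives a 2.5-fold lower number from compound 2 to compound 3 (0.40 log units; beyond the scatter), so the chloro on this aromatic carbon can now be read directly against hydrogen, whereas the earlier pair offered only a comparison with methyl. Hydrogen and methyl at this carbon are not separated, at a 1.2-fold higher number from compound 1 to compound 3 (0.07 log units; within the scatter), which leaves the chloro of compound 2 as the one group of the three that stands apart, with compound 1 and compound 3 together on the lower side of it. Nothing available gives a reason for the chloro standing apart in this way.

From the compounds shown here alone, these compounds carry only hydrogen, methyl and chloro at this carbon, so it remains open whether a fluoro, a methoxy, an amine or a carboxylic acid there would fall with hydrogen and methyl or with chloro. Going by these compounds, the steps also rest on a single shared core and on this assay alone, and whether the difference between chloro and hydrogen carries over to another core or another read-out stays open.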